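The source may hold more compounds than are shown below. What is called first, only, known or untested is meant among the compounds shown, and "the series" means these compounds.

Of the compounds shown here, three sharing one core have been measured in a functional assay on CCRF-CEM cells (Homo sapiens) for antiproliferative activity, read by MTT assay, with a stated time of 48 h, tested at 100 uM; on this read-out higher numbers stand for a weaker effect at the one concentration tested and lower numbers for a stronger effect. Compound 1 `OC(CCn1nc2c(Br)c(Br)c(Br)c(Br)c2n1)c1cccc(Br)c1` gives 0% in this assay. Compound 2 `OC(CCn1nc2c(Br)c(Br)c(Br)c(Br)c2n1)c1ccc(F)cc1` gives 0%. Compound 3 `OC(CCn1nc2c(Br)c(Br)c(Br)c(Br)c2n1)c1ccccc1` gives 0%. For the measured compounds named here, compound 3 therefore stands level with compounds 1 and 2 at the digits reported; its nearest neighbour is compound 1 and its furthest is compound 2, yet no pair separates beyond the scatter. The recorded steps say the same: no change at the digits printed from compound 1 to compound 2 (within the scatter), no change at the digits printed from compound 1 to compound 3 (within the scatter) and no change at the digits printed from compound 2 to compound 3 (within the scatter).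

Compound 4 `OC(CCn1nc2c(Br)c(Br)c(Br)c(Br)c2n1)c1ccc(Cl)cc1` has not yet been measured. It differs from compound 3 in one place: chloro in place of hydrogen on an aromatic carbon. The entering group sits on an aromatic carbon of a six-membered aromatic ring of carbon only, para to a large group.

Going by the values given here, the steps that bear on this change are those that alter the same ring: no change at the digits printed from compound 2 to compound 3 (within the scatter), where hydrogen replaces fluoro on an aromatic carbon, and no change at the digits printed from compound 1 to compound 3 (within the scatter), where hydrogen replaces bromo on an aromatic carbon. Both lie within the scatter, as does no change at the digits printed from compound 1 to compound 2 (within the scatter). Nothing among the measured compounds therefore gives reason to expect a step beyond the scatter in this assay in either direction. The expected step is no change at the digits printed from compound 3 to compound 4 (within the scatter). Compound 4 is thus estimated at 0%, with a range from 0% to 10%.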

Compound 4, a percentage reported as activity, at one concentration (the size of the read-out at that concentration, not a potency): 0%
For compound 4 middle estimate and measured number coincide at the digits printed; the measured number falls inside the stated range.
By their numbers in this assay, from the lowest: compounds 1, 2, 3 and 4 (each within the scatter of the next).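

With chloro on the aromatic carbon para to a large group, three groups are now seen at this place, hydrogen, fluoro and chloro, and the step from phenyl to 4-chlorophenyl reads no change at the digits printed from compound 3 to compound 4 (within the scatter) in this assay. Exchanging one halogen for the other at this same place gives no change at the digits printed from compound 2 to compound 4 (within the scatter), so this read-out does not tell chloro from fluoro here. Moving to the other substitution on the ring gives no change at the digits printed from compound 1 to compound 4 (within the scatter), so the 4-chlorophenyl and 3-bromophenyl compounds also stand level, and the four compounds offer no ranking among the ring substituents shown. Nothing given here offers an explanation for this flat result.

On these data alone, what remains open is whether a different group on this ring, such as an amine, a carboxylic acid or a methoxy group, would move the read-out away from the shared value. As far as these compounds go, it is equally open whether a longer chain between the shared core and the ring, or removal of the hydroxyl group on that chain, would separate compounds that these four leave level.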